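Fluorine on the Phenyl Ring: Compound 2 to Compound 3

This account rests on a few compounds, and the source may have more. Where it says the series, first, only, none or still open, it means among the compounds named here.

Compound 2 `O=c1[nH]cc(S(=O)(=O)Nc2ccc(-c3cn(-c4ccccc4)nn3)cc2)c(=O)[nH]1` and compound 1 `O=c1[nH]cc(S(=O)(=O)Nc2cccc(-c3cn(-c4cccc(Cl)c4)nn3)c2)c(=O)[nH]1` share a core and differ in how the triazole and its aryl substituent are arranged. In a functional assay on OVCAR-3 cells (Homo sapiens) for antiproliferative activity, read by MTT assay, with a stated time of 24 h (on this read-out higher numbers stand for weaker inhibition and lower numbers for stronger inhibition), compound 1 gives 3410 nM, while compound 2 gives 18000 nM, the highest of the two numbers; the gap between them lies beyond the usual scatter. Compound 3 `O=c1[nH]cc(S(=O)(=O)Nc2ccc(-c3cn(-c4ccccc4F)nn3)cc2)c(=O)[nH]1` has not yet been measured. It differs from compound 2 by fluoro in place of hydrogen on an aromatic carbon. Among the compounds with values here, no measured pair in this set shows the effect of such a change, so any expectation must rest on compound 2 alone. Since a single fluorine is a small addition, the step from compound 2 to compound 3 in this assay is expected to be modest and is not expected to go clearly beyond the scatter in either direction, a 1.5-fold lower number from compound 2 to compound 3 (0.18 log units; within the scatter). Compound 3 is therefore estimated at 12000 nM, with a range from 4000 nM to 40000 nM.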

Compound 3, half-maximal inhibitory concentration: 8030 nM
For compound 3 the middle estimate is 1.5-fold (0.17 log units) above the measured one, and the stated range covers the measured number.
By their numbers in this assay, from the lowest: compound 1; then compound 3; then compound 2.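

In this assay, within the data shown here, the change from phenyl to 2-fluorophenyl gives a 2.2-fold lower number from compound 2 to compound 3 (0.35 log units; beyond the scatter) and so supplies the only one-place comparison in this set. It shows that this small change, one fluorine atom on an aromatic carbon ortho to a large group, is enough to move the number past the usual scatter, though the step remains modest. The earlier compounds shown here differed in more than one place and could not show what this position does on its own.

From the compounds shown here alone, whether chloro, methoxy or an amine on the same carbon would move the number further or the other way stays open, as does the outcome of fluoro on the other carbons of that ring. Nothing shown here gives a reason for the step.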